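The source may report more compounds than this note shows. Statements on the series, on what has been measured and on what is new or still open speak of the compounds shown alone.

The measured compounds, all in the same cytotoxicity read-out:

Compound 1 `COc1ccc2[nH]cc(C3(c4c[nH]c5ccc(OC)cc45)C(=O)Nc4ccccc43)c2c1`: 2200 nM
Compound 2 `O=C1Nc2ccccc2C1(c1c[nH]c2ccc(Cl)cc12)c1c[nH]c2ccc(Cl)cc12`: 8100 nM
Compound 3 `COc1ccc2[nH]cc(C3(c4c[nH]c5ccc(OC)cc45)C(=O)Nc4ccc(F)cc43)c2c1`: 3600 nM

In a functional assay on DU-145 cells (Homo sapiens) for cytotoxicity, read by MTT assay, with a stated time of 48 h (on this read-out higher numbers stand for weaker inhibition and lower numbers for stronger inhibition), compound 1 gives 2200 nM, while compound 3 gives 3600 nM. Compound 3 differs from compound 1 by fluoro in place of hydrogen on an aromatic carbon, and the resulting step, a 1.6-fold higher number from compound 1 to compound 3 (0.21 log units; within the scatter), is small. Compound 2, which gives 8100 nM in this assay, carries a different core; the difference between the core of compound 1 and the core of compound 2 is not broken down here. Compound 2 stands as the highest number of the three, with its steps to both compound 1 and compound 3 beyond the scatter.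

Compound 4 `O=C1Nc2ccc(F)cc2C1(c1c[nH]c2ccc(Cl)cc12)c1c[nH]c2ccc(Cl)cc12` has not yet been measured. It differs from compound 2 by fluoro in place of hydrogen on an aromatic carbon, the same change as that from compound 1 to compound 3. Because the earlier step was a 1.6-fold higher number from compound 1 to compound 3 (0.21 log units; within the scatter), a step of similar size is expected, a 1.5-fold higher number from compound 2 to compound 4 (0.17 log units; within the scatter), in this assay. Compound 4 is therefore estimated at 12000 nM, expected to fall between 5000 nM and 28000 nM.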

Compound 4, half-maximal inhibitory concentration: 19600 nM
Compound 4: the middle estimate sits 1.6-fold (0.21 log units) below what was measured; measured number inside the range.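

In this assay the fluoro in place of hydrogen on an aromatic carbon of the core of compound 2 gives a 2.4-fold higher number from compound 2 to compound 4 (0.38 log units; beyond the scatter) on a core that carries chloro groups where compound 1 carries methoxy groups. Among the compounds shown here, this suggests that the change can be carried from the core of compound 1 to the core of compound 2 with a step of similar size in this one assay, but with only two pairs it does not show that the same would hold on any further core, and it does not explain why one step lies within the scatter and the other beyond it. The two steps themselves cannot be told apart: the same change on two cores in this assay, a 1.6-fold higher number (0.21 log units; within the scatter) from compound 1 to compound 3 and a 2.4-fold higher number (0.38 log units; beyond the scatter) from compound 2 to compound 4, 1.5-fold (0.17 log units) apart, within the scatter of two such steps.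

The compounds shown leave open what other groups at this place, such as a nitrile, an amine or a carboxylic acid, would do to the number on either core. They also leave open whether the fluoro step keeps its size in any other cell-based read-out.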